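This account rests on a few compounds, and the source may have more. Where it says the series, first, only, none or still open, it means among the compounds named here.

In a functional assay on DU-145 cells (Homo sapiens) for cytotoxicity, read by sulforhodamine B assay, with a stated time of 48 h (on this read-out higher numbers stand for weaker inhibition and lower numbers for stronger inhibition), two compounds sharing one core have been measured. Compound 1 (`C[C@H]1CC[C@@H]2[C@@H](OC(=O)[C@]23CC(c2c(Cl)cccc2Cl)=NO3)[C@]2(C)C(=O)C=C[C@@]12O`) gives 38000 nM, while compound 2 (`C[C@H]1CC[C@@H]2[C@@H](OC(=O)[C@]23CC(c2ccc([N+](=O)[O-])cc2)=NO3)[C@]2(C)C(=O)C=C[C@@]12O`) gives 7000 nM, the lower of the two numbers and so the stronger inhibition so far. Compound 3 (`Cc1ccccc1C1=NO[C@]2(C1)C(=O)O[C@@H]1[C@H]2CC[C@H](C)[C@]2(O)C=CC(=O)[C@@]12C`) keeps the same core but carries 2-methylphenyl in place of 4-nitrophenyl on a carbon with a double bond to nitrogen.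

Within the data shown here, only one measured step bears on this change, and it involves the same place on the core. Replacing 2,6-dichlorophenyl with 4-nitrophenyl there gave a 5.4-fold lower number from compound 1 to compound 2 (0.73 log units; beyond the scatter), a modest step that lies beyond the scatter. The new group shares a substituent numbered 2 with the group of compound 1, at 38000 nM, so a move towards that weaker number is expected in this assay. Among the measured compounds shown here, with so few measurements, this is only a tentative expectation, and the size should be no larger than the one step seen. The expected change is a 2.1-fold higher number from compound 2 to compound 3 (0.33 log units; beyond the scatter). For compound 3 the estimated value is 15000 nM, with an expected range from 5000 nM to 45000 nM.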

Compound 3, half-maximal inhibitory concentration: 12000 nM
Beside the measured number, compound 3's estimate is 1.3-fold (0.10 log units) above it; the range from low to high includes it.
By their numbers in this assay, from the lowest: compounds 2 and 3 (each within the scatter of the next); then compound 1.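

In this assay, putting 2-methylphenyl in place of 4-nitrophenyl gives a 1.7-fold higher number from compound 2 to compound 3 (0.23 log units; within the scatter), so two groups that differ in their atoms and in their count of hydrogen-bond acceptors cannot be told apart at this position. The comparison with the other compound gives a 3.2-fold lower number from compound 1 to compound 3 (0.50 log units; beyond the scatter), which shows that a substituent numbered 2 does not by itself move the number towards that of compound 1: among these three compounds, only the group with two chlorines stands apart, and compound 3 goes against the simple expectation drawn from the shared numbering. No measurement at hand explains why 2,6-dichlorophenyl stands apart from the other two groups.

All three groups shown are substituted phenyl rings, so it stays open what plain phenyl, 2-chlorophenyl or 4-methylphenyl would give, and these would help separate the effect of the kind of substituent from that of its numbered place on the ring. Also open, on these data alone, is how this carbon would respond to something other than a phenyl ring, such as a short alkyl chain, an amine or a carboxylic acid.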